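Swapping Phenyl for Pyridin-3-yl on an Amine Nitrogen

The source may report more compounds than this note shows. Statements on the series, on what has been measured and on what is new or still open speak of the compounds shown alone.

Of the compounds shown here, two built on one shared core have been tested in a functional assay on LNCaP cells (Homo sapiens) for antiproliferative activity, read by CCK-8 assay, with a stated time of 6 days; a higher number here means a weaker inhibitor, a lower number a stronger inhibitor. Compound 1 `C[C@@H](Cn1ccc(-c2ccc(C#N)c(Cl)c2)n1)NC(=O)c1ccccc1F` carries an amide on its amine nitrogen; in this assay compound 1 gives 1810 nM. Compound 2 `C[C@@H](Cn1ccc(-c2ccc(C#N)c(Cl)c2)n1)Nc1ccccc1` carries a plain phenyl on that nitrogen instead; in this assay compound 2 gives 710 nM. Going by the values given here, the single step measured so far, a 2.5-fold lower number from compound 1 to compound 2 (0.41 log units; beyond the scatter), leaves compound 2 with the lower of the two numbers, which in this assay means the stronger inhibitor.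

Compound 3 `C[C@@H](Cn1ccc(-c2ccc(C#N)c(Cl)c2)n1)Nc1cccnc1` differs from compound 2 in one place only: pyridin-3-yl in place of phenyl on an amine nitrogen. Among the compounds with values here, no measured step touches this exchange; the step from compound 1 to compound 2 changed what hangs on the same nitrogen in a different way and gives no guidance on a ring nitrogen. With nothing to anchor a direction, the expectation is a change that stays within the scatter, a 1.3-fold higher number from compound 2 to compound 3 (0.10 log units; within the scatter), with room for either direction. Compound 3 is therefore estimated at 900 nM, with a range from 350 nM to 2500 nM.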

Compound 3, half-maximal inhibitory concentration: 430 nM
Beside the measured number, compound 3's estimate is 2.1-fold (0.32 log units) above it; the measured number falls inside the stated range.
By their numbers in this assay, from the lowest: compounds 3 and 2 (each within the scatter of the next); then compound 1.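

In this assay, the exchange of phenyl for pyridin-3-yl on the amine nitrogen gives a 1.7-fold lower number from compound 2 to compound 3 (0.22 log units; within the scatter) and so leaves the two rings indistinguishable at this position, even though pyridin-3-yl carries a ring nitrogen and a hydrogen-bond acceptor that phenyl does not. This position therefore accepts that exchange without a change that can be told from ordinary assay noise, something the earlier pair could not show, since it compared an amide with a plain phenyl. Against the amide, the pyridine compound gives a 4.2-fold lower number from compound 1 to compound 3 (0.62 log units; beyond the scatter) and so matches compound 2 in that both compounds with an aromatic ring directly on this nitrogen have lower numbers than compound 1, which has the (2-fluorophenyl)carbonyl group there.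

No measurement shown here accounts for these numbers or says what the ring nitrogen does at this position. Still open, from the compounds shown here alone, is how pyridin-2-yl or pyridin-4-yl would compare with pyridin-3-yl on this nitrogen, and whether a saturated ring such as piperidine or a simple ethyl chain would keep the number of compound 3.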